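The source may report more compounds than this note shows. Statements on the series, on what has been measured and on what is new or still open speak of the compounds shown alone.

Compound 1 `O=C(O)/C(S)=C/c1ccc(Br)cc1` gives 1500 nM in an assay on isolated protein for inhibition of Calpain-1 catalytic subunit (Sus scrofa); a higher number here means a weaker inhibitor, a lower number a stronger inhibitor.
Compound 3 `O=C(O)/C(S)=C/c1ccc(Cl)cc1` gives 15000 nM in this assay.
Compound 2 `O=C(O)/C(S)=C/c1cccc(I)c1` gives 23900 nM in this assay.

Among these three numbers compound 3 stands second highest. Its nearest neighbour is compound 2, whose number is within the usual scatter of it, so the two cannot be told apart; compound 1 is furthest away, with a step of a 10-fold higher number from compound 1 to compound 3 (1.00 log units; beyond the scatter) that is clearly beyond the scatter.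

Compound 4 `O=C(O)/C(S)=C/c1ccc(F)cc1` has not yet been measured. It differs from compound 3 in one place: fluoro in place of chloro on an aromatic carbon. Among the measured compounds shown here, only one measured step bears on this change, the exchange of one halogen-type group for another at the same place, and that is the step of a 10-fold higher number from compound 1 to compound 3 (1.00 log units; beyond the scatter), a modest rise in the number. Bromo to chloro raised the number; chloro to fluoro continues in that same direction of group, but whether the number keeps rising, stays level or turns round cannot be read from one step. A rise of comparable size, or something smaller, is the most natural expectation for this assay.

For compound 4 the estimate is 25000 nM, within a range from 8000 nM to 80000 nM, which would mean an expected step of a 1.7-fold higher number from compound 3 to compound 4 (0.22 log units; within the scatter).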

Compound 4, half-maximal inhibitory concentration: 5600 nM
For compound 4 the middle estimate is 4.5-fold (0.65 log units) above the measured one, and the stated range ends above it.
By their numbers in this assay, from the lowest: compound 1; then compound 4; then compounds 3 and 2 (each within the scatter of the next).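

In this assay the exchange of one halogen for another at this place on the ring does not move the number in a single direction: a 10-fold higher number from compound 1 to compound 3 (1.00 log units; beyond the scatter) for bromo to chloro is followed by a reversal, a 2.7-fold lower number from compound 3 to compound 4 (0.43 log units; beyond the scatter) for chloro to fluoro. Among the three compounds that carry a halogen at this place, chloro therefore gives the highest number rather than fluoro, yet the reversal does not win back all the ground, since there is still a 3.7-fold higher number from compound 1 to compound 4 (0.57 log units; beyond the scatter) for the direct exchange of bromo for fluoro, and the bromo of compound 1 keeps the lowest number of the three. No evidence is available to say what lies behind this order.

Going by these compounds, compound 2 carries its iodo at a different place on the ring, so it differs from these compounds in more than one respect, and how iodo would behave at the place studied here remains open. Also open, on these data alone, is whether a group that is not a halogen at this place, such as methyl, methoxy or an amine, would give a number lower than that of the bromo compound.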